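Furan in Place of Methoxyphenyl: What to Expect

This account rests on a few compounds, and the source may have more. Where it says the series, first, only, none or still open, it means among the compounds named here.

Compound 1 `COc1ccccc1-c1sc(N)c(C(=O)c2ccc(Cl)cc2)c1CC(C)(C)C` was tested in an assay on CHO cells for displacement of a labelled ligand from adenosine receptor A3 (Homo sapiens), read by scintillation counting, tested at 10 uM (on this read-out lower numbers stand for less inhibition and higher numbers for more inhibition at the one concentration tested (going by the name of the read-out)), where compound 1 gives 1%. Its nearest neighbour, compound 2 `CC(C)(C)Cc1c(Br)sc(N)c1C(=O)c1cccc(Cl)c1`, gives 1% in this assay; the two values lie within the scatter of repeated measurements, so neither can be called stronger. Both show only slight displacement of the labelled ligand at the single concentration used. Compound 3 `CC(C)(C)Cc1c(-c2ccco2)sc(N)c1C(=O)c1ccc(Cl)cc1` has not yet been measured. It differs from compound 1 in one place: furan-2-yl in place of 2-methoxyphenyl on an aromatic carbon. Among the compounds with values here, no pair of measured compounds shows what such a swap does here, so the expectation rests on the low value of compound 1 alone. Given that compound 1 gives 1%, the expected step is a number 2 percentage points higher from compound 1 to compound 3 (within the scatter), meaning no change beyond the scatter in either direction. For compound 3 the estimated inhibition is 3%, with a range from 0% to 15%.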

Compound 3, a percentage reported as inhibition, at one concentration (the size of the read-out at that concentration, not a potency): 1%
Estimate against measurement, compound 3: 2 percentage points above; the range from low to high includes it.
By their numbers in this assay, from the lowest: compounds 1, 2 and 3 (each within the scatter of the next).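

In this assay, furan-2-yl in place of 2-methoxyphenyl on the aromatic carbon next to the ring sulfur gives no change at the digits printed from compound 1 to compound 3 (within the scatter). Within the data shown here, this is the first direct look at this position: a smaller aromatic group, with 5 heavy atoms instead of 8, does not bring out any displacement of the labelled ligand beyond the scatter, although a step between two such low readings says little about how much the position matters. Nothing measured here offers an explanation for this result.

On these data alone, it remains open whether any group on this carbon can raise the reading, for example an amine such as piperazine or a carboxylic acid. Also open, as far as these compounds go, is whether furan-2-yl would read differently with another group in place of neopentyl.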